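The source may hold more compounds than are shown below. What is called first, only, known or untested is meant among the compounds shown, and "the series" means these compounds.

Compound 1 `C=C(C)[C@@H]1CC[C@](C)(O)[C@H]1/C=C/C(C)=C/[C@@H]1C[C@@]23[C@H](OCCC[C@@H]2/C(=C(/C)C=O)CC[C@]3(C)O)O1`: > 10000 nM (a limit)
Compound 2 `C=C(C)[C@@H]1CC[C@](C)(O)[C@H]1/C=C/C(C)=C/[C@@H]1C[C@@]2([C@H](OC)O1)[C@H](CCCO)/C(=C(/C)C=O)CC[C@]2(C)O`: > 10000 nM (a limit)
Compound 3 `C=C(C)[C@@H]1CC[C@](C)(O)[C@H]1/C=C/C(C)=C/[C@@H]1C[C@@]2([C@H](OC)O1)[C@H](CCCO)/C(=C(\C)C=O)CC[C@]2(C)O`: > 10000 nM (a limit)

All three compounds were tested in a functional assay on MCF7 cells (Homo sapiens) for cytotoxicity, read by MTT assay, with a stated time of 72 h (a higher number here means a weaker inhibitor, a lower number a stronger inhibitor), and the record so far is the limit of > 10000 nM in this assay, at which 3 of the 3 values shown sit. Compound 3 therefore has no number of its own, only a limit, and the same holds for the two values beside it.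

Compound 4 `C=C(C)[C@H]1CC[C@@](C)(O)[C@@H]1/C=C/C(C)=C/[C@@H]1C[C@@]2([C@H](OC)O1)[C@H](CCCO)/C(=C(\C)C=O)CC[C@]2(C)O` is the next case, and its relation to compound 3 is this: the two compounds have the same atoms and bonds and differ only in configuration as drawn: 3 of 11 stereo elements differ; a stereocentre at a saturated ring carbon is drawn R in compound 3 and S in compound 4; a stereocentre at a saturated ring carbon is drawn S in compound 3 and R in compound 4; a stereocentre at a saturated ring carbon is drawn S in compound 3 and R in compound 4. Nothing leaves and nothing enters, so the whole change lies in those stereocentres at saturated ring carbons.

Within the data shown here, the one measured step that bears on this is a step that the two limits leave unreadable from compound 2 to compound 3. It is also a change of configuration alone, as the fact that compounds 2 and 3 differ only in the configuration as drawn shows, but its size cannot be read, so it gives no measure of what such a change does in this assay. Compound 3 carries the limit of > 10000 nM, and compound 4 is expected to stay at that limit as well.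

The expected step is a step that the limit leaves unreadable from compound 3 to compound 4, an estimate with no direction beyond the scatter. For compound 4 the estimated value is 15000 nM, with an expected range from 5000 nM to 40000 nM.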

Compound 4, half-maximal inhibitory concentration: > 10000 nM
Compound 4 gave a limit, no number; the forecaster's own chance of this, stated with the estimate: 85%; the middle value does not contradict the limit.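

In this assay compound 4 gives > 10000 nM, which is a limit and not a number. Among these compounds, no step among compound 2, compound 3 and compound 4 can therefore be read. The compounds shown leave open whether any of these changes of configuration alters the result in this assay, and what value any of these compounds would actually reach.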